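Series notes: triazole aryl swap on the shared core

The source may report more compounds than this note shows. Statements on the series, on what has been measured and on what is new or still open speak of the compounds shown alone.

Compound 1, `N#CC1=C(N)Oc2c(N)cc3nc4ccccc4nc3c2C12C(=O)N(Cc1cnnn1-c1cccc(C(F)(F)F)c1)c1ccccc12`, in an ADME assay on L02 cells (Homo sapiens) for antiproliferative activity, read by MTT assay, with a stated time of 48 h (on this read-out higher numbers stand for weaker inhibition and lower numbers for stronger inhibition), gives 38100 nM. Compound 2, `Cc1ccc(-n2nncc2CN2C(=O)C3(C(C#N)=C(N)Oc4c(N)cc5nc6ccccc6nc5c43)c3ccccc32)cc1Cl`, in this assay reaches only a limit and not a number, at > 50000 nM. Going by the values given here, the one measured step goes an at least 1.3-fold higher number from compound 1 to compound 2 (0.11 log units; that floor lies within the scatter), which is all the series shows on this kind of exchange; it also marks (the limit of > 50000 nM in this assay, at which 1 of the 2 values shown sits), so the true size of that step is open. Compound 3, `Cc1cc(C)c(-n2nncc2CN2C(=O)C3(C(C#N)=C(N)Oc4c(N)cc5nc6ccccc6nc5c43)c3ccccc32)c(C)c1`, differs from compound 2 by 2,4,6-trimethylphenyl in place of 3-chloro-4-methylphenyl on an aromatic nitrogen. Among the compounds with values here, only the step from compound 1 to compound 2 bears on this change, and it leaves both compounds weak in this assay. The expectation for compound 3 is therefore no move beyond the scatter, with a high chance that this assay again returns only a limit. The step is estimated as a step that the limit leaves unreadable from compound 2 to compound 3. Compound 3 is estimated at 55000 nM, within 22000 nM to 140000 nM.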

Compound 3, half-maximal inhibitory concentration: > 50000 nM
Compound 3: a limit, no number; the forecaster's own chance of this, stated with the estimate: 65%; the middle value lies beyond the limit too.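

In this assay, the aryl group on this aromatic nitrogen can now carry methyl groups alone, with no chlorine or fluorine, and compound 3 still returns only a limit rather than a number. On these data alone, the exchange of 3-(trifluoromethyl)phenyl for 2,4,6-trimethylphenyl gives an at least 1.3-fold higher number from compound 1 to compound 3 (0.11 log units; that floor lies within the scatter), so the true size of this step remains open. The step from compound 2 to compound 3 cannot be read, and the read-out now gives little resolution at this position: the limit of > 50000 nM in this assay, at which 2 of the 3 values shown sit.

Still open, as far as these compounds go, is whether any aryl group here moves compound 3 or compound 2 to a measurable value. A phenyl ring bearing a dimethylamino group or a carboxylic acid, or a longer chain in place of the aryl group, would test this position further.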